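Removal of the benzo-ring methoxy across two cores

A few compounds are considered here, and "the series" means these few. Any claim that something is new, unique, unknown or untested is made for them only; others in the source may bear on it.

Compound 1 `COc1ccc(-c2cc(=S)c3ccc(OC)cc3o2)cc1` gives 3340 nM in an in vitro assay on BTI-TN-5B1-4 cells for inhibition of Amine oxidase [flavin-containing] B (Homo sapiens); on this read-out higher numbers stand for weaker inhibition and lower numbers for stronger inhibition. Compound 2 `COc1ccc(-c2cc(=S)c3ccccc3o2)cc1` gives 480 nM; the change hydrogen in place of methoxy on an aromatic carbon produced a 7.0-fold lower number from compound 1 to compound 2 (0.84 log units; beyond the scatter). Compound 3 `COc1ccc2c(c1)OC(c1ccc(C)cc1)CC2=O` has a different core from compound 1; the difference between the two cores is not broken down here. In this assay compound 3 gives 550 nM, close to compound 2. Compound 4 `Cc1ccc(C2CC(=O)c3ccccc3O2)cc1` is not yet measured; it differs from compound 3 by hydrogen in place of methoxy on an aromatic carbon, the same change as from compound 1 to compound 2, since both place descriptions read alike. Going by the values given here, the expectation is a step of a 3.4-fold lower number from compound 3 to compound 4 (0.54 log units; beyond the scatter), somewhat smaller than the earlier one because the core carrying a 7.0-fold lower number from compound 1 to compound 2 (0.84 log units; beyond the scatter) is not the core of compound 3, and only one prior example exists. Compound 4 is therefore estimated at 160 nM, with a range from 50 nM to 500 nM.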

Compound 4, half-maximal inhibitory concentration: 2070 nM
For compound 4 the middle estimate is 13-fold (1.11 log units) below the measured one; the measured number lies above the stated range.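

On the core of compound 3, hydrogen in place of methoxy on an aromatic carbon gives a 3.8-fold higher number from compound 3 to compound 4 (0.58 log units; beyond the scatter), so in this assay the step on the core of compound 1 does not predict the step on the core of compound 3. The two steps run in opposite directions: the same change on two cores in this assay, a 7.0-fold lower number (0.84 log units; beyond the scatter) from compound 1 to compound 2 and a 3.8-fold higher number (0.58 log units; beyond the scatter) from compound 3 to compound 4, 26-fold (1.42 log units) apart, beyond the scatter of two such steps This shows that the outcome of the change depends on the core for these two pairs; it does not show which part of the difference between the cores matters, and two pairs give no rule for a third core.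

The compounds shown carry only methoxy or hydrogen at this place. Going by these compounds, how an amine or a carboxylic acid there would behave on either core remains open.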